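The compounds below may be only part of what the source reports. "The series", "measured", "known", "first", "only" and "open" are said of these compounds alone.

Measured so far:
- compound 1 `O[C@](Cc1ccccc1-c1ccccc1)(c1ccccc1)[C@@H]1CNCCO1`: 2.9% in an assay on isolated protein for displacement of a labelled ligand from sodium-dependent dopamine transporter (Homo sapiens), tested at 1000 nM; on this read-out lower numbers stand for less inhibition and higher numbers for more inhibition at the one concentration tested (going by the name of the read-out)
- compound 2 `COc1cccc(C[C@@](O)(c2ccccc2)[C@@H]2CNCCO2)c1`: 4.3% in this assay

Both numbers are small. Compound 1 has the lower of the two, but the gap to compound 2 lies within the scatter, so the two cannot be told apart. Compound 3 `O[C@](Cc1ccccc1Cl)(c1ccccc1)[C@@H]1CNCCO1` is not yet measured; it differs from compound 1 by chloro in place of phenyl on an aromatic carbon. Going by the values given here, no step between measured compounds exists to lean on, and compound 1 sits near the floor of this assay, so no step beyond the scatter is expected in either direction. The expected value for compound 3 in this assay is 5%, within 0% to 20%. Thus the expected step is a number 2.1 percentage points higher from compound 1 to compound 3 (within the scatter).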

Compound 3, a percentage reported as inhibition, at one concentration (the size of the read-out at that concentration, not a potency): 20.8%
Compound 3: middle estimate off by 15.8 percentage points, on the low side; measured number outside the range, above it.
By their numbers in this assay, from the lowest: compounds 1 and 2 (each within the scatter of the next); then compound 3.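

Replacing phenyl with chloro on this aromatic carbon, ortho to a large group, gives a number 17.9 percentage points higher from compound 1 to compound 3 (beyond the scatter) in this assay. So this position responds to the choice of group, and a whole ring can give way to a single chlorine atom without any loss of inhibition at the one concentration tested. Nothing available explains the rise. Still open, from the compounds shown here alone, is whether the gain belongs to chloro itself or to the loss of phenyl. Fluoro or methyl on the same carbon would help to separate the two.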